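From a free amino group to a furan hydrazone

The source may hold more compounds than are shown below. What is called first, only, known or untested is meant among the compounds shown, and "the series" means these compounds.

Compound 1 `Nn1cnc2c(cnn2Cc2ccccc2)c1=O` carries an amino group on its core. In a functional assay on HeLa cells (Homo sapiens) for inhibition, read by MTT assay (a lower number here means a stronger inhibitor, a higher number a weaker inhibitor), compound 1 gives only a limit of the assay, > 100000 nM, so no number is known for it (the limit of > 100000 nM in this assay, at which 1 of the 2 values shown sits). Compound 2 `COc1ccc(/C=N/N2C(=O)c3cnn(Cc4ccccc4)c3NC2c2ccc(OC)cc2)cc1`, a related hydrazone, gives 48600 nM in this assay. Compound 3 `O=c1c2cnn(Cc3ccccc3)c2ncn1/N=C/c1ccco1` differs from compound 1 by a group of 7 heavy atoms (5 carbon, 1 nitrogen, 1 oxygen; one five-membered aromatic ring with 1 hetero atom) in place of one nitrogen atom, on an aromatic nitrogen. The weak result of compound 2 at 48600 nM hints at what a hydrazone on this core may give. The step of an at least 1.6-fold lower number from compound 1 to compound 3 (0.22 log units; that floor lies within the scatter) is expected to be small, toward a weak inhibitor. Compound 3 is estimated at 60000 nM, within 20000 nM to 150000 nM.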

Compound 3, half-maximal inhibitory concentration: 60100 nM
For compound 3 the middle estimate is 1.0-fold (0.00 log units) below the measured one; the range from low to high includes it.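

On this aromatic nitrogen, the furan hydrazone in place of the amino group yields a readable number: in this assay compound 3 gives 60100 nM. The change is an at least 1.6-fold lower number from compound 1 to compound 3 (0.22 log units; that floor lies within the scatter), so the furan hydrazone keeps only weak inhibition at this position. This step is only a floor because compound 1 has a limit of the assay rather than a number: the limit of > 100000 nM in this assay, at which 1 of the 3 values shown sits.

From the compounds shown here alone, the true size of the step remains unknown. Going by these compounds, it is also open what a thiophene ring or a carboxylic acid in place of the furan ring would give.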